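The source may report more compounds than this note shows. Statements on the series, on what has been measured and on what is new or still open speak of the compounds shown alone.

Measured compounds:
- compound 1 `O=C(NCc1ccc(S(=O)(=O)N2CCOCC2)cc1)c1cc2ccncc2o1`: 32 nM
- compound 2 `CC(C)N1CCC(S(=O)(=O)c2ccc(CNC(=O)c3cc4ccncc4o3)cc2)CC1`: 71 nM
- compound 3 `CN=S(=O)(c1ccccc1)c1ccc(CNC(=O)c2cc3ccncc3o2)cc1`: 5 nM

All three share one core and differ only in the group carried by the sulfur atom on the benzyl ring. In an assay for inhibition of Nicotinamide phosphoribosyltransferase (Homo sapiens), with stated times of 15 min and 30 min (a lower number here means a stronger inhibitor, a higher number a weaker inhibitor), compound 2 gives 71 nM, the highest number of the three. Its nearest neighbour is compound 1, which differs only by the ring on the sulfonyl sulfur; the step of a 2.2-fold higher number from compound 1 to compound 2 (0.35 log units; beyond the scatter) is modest. Among the compounds with values here, compound 3, which carries a different kind of sulfur group, gives 5 nM; no single step links it to compound 2, and the two values simply sit far apart.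

Compound 4 `CC(C)n1cc(S(=O)(=O)c2ccc(CNC(=O)c3cc4ccncc4o3)cc2)cn1` has not been measured. It differs from compound 2 in one place: 1-isopropyl-1H-pyrazol-4-yl in place of 1-isopropylpiperidin-4-yl on a sulfonyl sulfur. Within the data shown here, the only step that bears directly on this position is the one from compound 1 to compound 2, which was modest. Swapping one ring for another on this sulfur is therefore expected to move the number by a small amount at most, and the direction is uncertain; the expected step is a 1.8-fold lower number from compound 2 to compound 4 (0.25 log units; within the scatter). For compound 4 the estimate in this assay is 40 nM, with a range from 12 nM to 130 nM.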

Compound 4, half-maximal inhibitory concentration in the Nicotinamide phosphoribosyltransferase assay: 10 nM
For compound 4 the middle estimate is 4.0-fold (0.60 log units) above the measured one; the whole stated range lies above it.
By their numbers in the Nicotinamide phosphoribosyltransferase assay, from the lowest: compounds 3 and 4 (each within the scatter of the next); then compound 1; then compound 2.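

In the Nicotinamide phosphoribosyltransferase assay the ring on the sulfonyl sulfur proves able to shift the number well beyond the scatter, which the modest step from compound 1 to compound 2 did not reveal: the aromatic 1-isopropyl-1H-pyrazol-4-yl gives a 7.1-fold lower number from compound 2 to compound 4 (0.85 log units; beyond the scatter), and a 3.2-fold lower number from compound 1 to compound 4 (0.51 log units; beyond the scatter). So this ring gives a lower number than either of the two non-aromatic rings, whether or not that ring carries an isopropyl group. In a physicochemical assay for solubility, measured as kinetic solubility, with a stated time of 24 h, at pH 7.4 (on this read-out lower numbers stand for lower solubility and higher numbers for higher solubility), compound 2 gives 183000 nM and compound 4 gives 12000 nM. The same swap also carries a large cost in the physicochemical assay: the measured solubility of compound 2, 183000 nM, and of compound 4, 12000 nM, a 15-fold lower number (1.18 log units; beyond the scatter)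

Within the data shown here, it remains open whether the two changes can be separated, since only this one pair shows both read-outs. A hydroxyethyl chain or a dimethylamino group in place of the isopropyl group on the pyrazole could test whether the lower inhibition number survives while solubility recovers.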